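Extending a Hydroxycarbamoyl Chain When Every Value Is a Limit

The source may report more compounds than this note shows. Statements on the series, on what has been measured and on what is new or still open speak of the compounds shown alone.

Compound 3 (`C=CC(=O)Nc1cc2c(Nc3ccc(F)c(Cl)c3)ncnc2cc1OCc1cn(CCCC(=O)NO)nn1`) ends in a 3-(hydroxycarbamoyl)propyl chain. In a functional assay on A549 cells (Homo sapiens) for antiproliferative activity, read by MTT assay, with a stated time of 72 h (on this read-out higher numbers stand for weaker inhibition and lower numbers for stronger inhibition), compound 3 gives > 50000 nM, which is a limit and not a number. Compound 1 (`C=CC(=O)Nc1cc2c(Nc3ccc(F)c(Cl)c3)ncnc2cc1OCc1cn(CCC(=O)NO)nn1`) has the same core with a 2-(hydroxycarbamoyl)ethyl chain, and in this assay compound 1 gives > 50000 nM, also a limit. Compound 2 (`C=CC(=O)Nc1cc2c(Nc3cccc(Cl)c3F)ncnc2cc1OCc1cn(CCCCC(=O)NO)nn1`) carries a 4-(hydroxycarbamoyl)butyl chain, and in this assay compound 2 gives > 50000 nM, again a limit. Compound 3 therefore has no exact position on the scale and stands with the others at the limit of > 50000 nM in this assay, at which 3 of the 3 values shown sit.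

Compound 4 (`C=CC(=O)Nc1cc2c(Nc3ccc(F)c(Cl)c3)ncnc2cc1OCc1cn(CCCCC(=O)NO)nn1`) lengthens the chain of compound 3: (hydroxycarbamoyl)methyl in place of hydroxycarbamoyl on a saturated chain carbon, three bonds along the chain from an aromatic nitrogen. In words, this is (hydroxycarbamoyl)methyl in place of hydroxycarbamoyl on a saturated chain carbon, three bonds along the chain from an aromatic nitrogen, or 3-(hydroxycarbamoyl)propyl to 4-(hydroxycarbamoyl)butyl. The closest measured change is a step that the two limits leave unreadable from compound 1 to compound 3, the same lengthening made one bond nearer the aromatic nitrogen, so it offers no size to carry over. With no sign of activity in any of these compounds, a further limit is the likeliest report for compound 4. The expected outcome is a number no higher from compound 3 to compound 4 (the limit leaves the size open), with no direction foreseen. For compound 4 the estimated value is 50000 nM, with an expected range from 15000 nM to 100000 nM.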

Compound 4, half-maximal inhibitory concentration: > 50000 nM
Compound 4 was reported as a limit; the forecaster's own chance of this, stated with the estimate: 80%; the middle value sits exactly at the limit.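

In this assay compound 4 gives > 50000 nM, a limit and not a number. The steps joining compound 4 to compounds 1, 2 and 3 cannot be read, as all four compounds share one limit: the limit of > 50000 nM in this assay, at which 4 of the 4 values shown sit.

The compounds shown leave open how far each true value lies from that limit, and whether chain length or the change from 3-chloro-2-fluorophenyl to 3-chloro-4-fluorophenyl alters activity at all.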